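The compounds below may be only part of what the source reports. "The series", "measured", "known", "first", "only" and "open" are said of these compounds alone.

Compound 1 `C[Se]/C(=N\C(=O)c1cc2ccccc2s1)NC(=O)c1cc2ccccc2s1` carries a methyl group on its selenium atom and two identical aromatic amide arms on the shared core. Within the data shown here, in a functional assay on HT-29 cells (Homo sapiens) for cytotoxicity, read by MTT assay, with a stated time of 72 h (on this read-out lower numbers stand for stronger inhibition of growth and higher numbers for weaker inhibition of growth), compound 1 gives 5620 nM, which stands second highest among the three numbers measured so far. Compound 2 `O=C(/N=C(/NC(=O)c1csc([N+](=O)[O-])c1)[Se]Cc1ccccc1)c1csc([N+](=O)[O-])c1`, which carries a benzyl group on selenium and different aromatic amide arms, gives 9250 nM in this assay, a number within the usual scatter of compound 1. Compound 3 `C[Se]/C(=N\C(=O)c1cnc2ccccc2c1)NC(=O)c1cnc2ccccc2c1`, which keeps the methyl on selenium but again carries other aromatic amide arms, gives 200 nM in this assay, the lowest number of the three and well beyond the scatter from compound 1.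

Compound 4 `O=C(/N=C(/NC(=O)c1cc2ccccc2s1)[Se]Cc1ccccc1)c1cc2ccccc2s1` has not yet been measured. It differs from compound 1 in one place: phenyl in place of hydrogen on a saturated chain carbon bound to a selenium atom. Among the measured compounds shown here, no pair of measured compounds differs only in this way, so the size of this step is not known directly. Compound 2 carries the benzyl group and lands in the same range as compound 1, but its amide arms also differ, so it cannot stand in for the step alone. The expectation is therefore a change no larger than the scatter, in either direction, written as a 1.1-fold higher number from compound 1 to compound 4 (0.03 log units; within the scatter). Compound 4 is estimated at 6000 nM, with a range from 2000 nM to 18000 nM.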

Compound 4, concentration for 50% growth inhibition: 6510 nM
Estimate against measurement, compound 4: 1.1-fold (0.04 log units) below, within the range that was stated.
By their numbers in this assay, from the lowest: compound 3; then compounds 1, 4 and 2 (each within the scatter of the next).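

With the amide arms now held the same, the change from methyl to benzyl can be read on its own: in this assay the step is a 1.2-fold higher number from compound 1 to compound 4 (0.06 log units; within the scatter) and stays within the usual scatter of repeated measurements. Compound 2 could not show this, since it carries the benzyl group together with different arms. For this pair, then, a phenyl in place of hydrogen on a saturated chain carbon bound to a selenium atom leaves the growth-inhibition number indistinguishable from that of the methyl compound, so the added ring shows no measurable gain or loss here. Nothing available here bears on why the two compounds read alike.

This single step does not tell whether a longer chain such as propyl, or a benzyl ring carrying an amine or a carboxylic acid, would also leave the number in place. It also leaves open whether the methyl to benzyl change would stay as small on the amide arms of compound 3, where the same step cannot yet be read.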